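The compounds below may be only part of what the source reports. "The series", "measured", "known", "first", "only" and "open" are said of these compounds alone.

Series notes. Within the data shown here, compound 1 `Cc1cccc(-c2nnc(SCCCN3CCN(c4ccccn4)CC3)[nH]2)c1` is the one member with a number in a functional assay on U-937 cells (Homo sapiens) for cytotoxicity, read by MTT assay, with a stated time of 24 h; on this read-out higher numbers stand for weaker inhibition and lower numbers for stronger inhibition: compound 1 gives 52300 nM. Compound 2 `CCN1CCN(CCCSc2nnc(-c3ccccc3Cl)[nH]2)CC1` reaches only a limit of this assay, reading > 300000 nM. Compound 3 `Clc1ccccc1-c1nnc(SCCCN2CCN(c3ccccn3)CC2)[nH]1` likewise stops at a limit, reading > 300000 nM. Compound 3 therefore sits at the limit of > 300000 nM in this assay, at which 2 of the 3 values shown sit, so its standing on the shown numbers is an open range rather than a position. Among the measured compounds shown here, the one readable step into compound 3 is an at least 5.7-fold higher number from compound 1 to compound 3 (0.75 log units; beyond the scatter); the other, a step that the two limits leave unreadable from compound 2 to compound 3, cannot be sized.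

Compound 4 `c1ccc(Cc2nnc(SCCCN3CCN(c4ccccn4)CC3)[nH]2)cc1` is not yet measured. It differs from compound 3 by benzyl in place of 2-chlorophenyl on an aromatic carbon. The only measured step that touches the group at this position is the one from compound 1, where 2-chlorophenyl in place of 3-methylphenyl gave an at least 5.7-fold higher number from compound 1 to compound 3 (0.75 log units; beyond the scatter); benzyl is a third group at the same position, and no shown step tells whether it behaves more like one or the other. A step out of a limit cannot be read as a number, so the expected step of an at least 2.0-fold lower number from compound 3 to compound 4 (0.30 log units; that floor lies within the scatter) rests on compound 1 alone and is weakly founded. Compound 4 is therefore estimated at 150000 nM, within 40000 nM to 400000 nM, with a real chance that it again reaches only a limit.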

Compound 4, half-maximal inhibitory concentration: 163000 nM
Beside the measured number, compound 4's estimate is 1.1-fold (0.04 log units) below it, and the stated range covers the measured number.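

In this assay, the position on the aromatic carbon between two ring nitrogen atoms now holds a second group that returns a true number, and the change from 3-methylphenyl to benzyl can be sized: a 3.1-fold higher number from compound 1 to compound 4 (0.49 log units; beyond the scatter). With the same count of heavy atoms on both sides, benzyl in place of 2-chlorophenyl gives an at least 1.8-fold lower number from compound 3 to compound 4 (0.26 log units; that floor lies within the scatter), so this step rests on a limit and does not yet separate the two groups beyond the scatter. A measurable number at this position is therefore not confined to 3-methylphenyl, although compound 1 still carries the lowest number of the three compounds that keep pyridin-2-yl on the ring nitrogen.

From the compounds shown here alone, whether an unsubstituted phenyl or a longer chain such as 2-phenylethyl at this position would fall nearer compound 1 or compound 4 remains open. The effect of pyridin-2-yl against ethyl on the ring nitrogen also stays open, and the step between compound 2 and compound 3 cannot be read because both stop at the same limit: the limit of > 300000 nM in this assay, at which 2 of the 4 values shown sit.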